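Aromatic group replacing a propyl chain on a thio-substituted nucleoside

This account rests on a few compounds, and the source may have more. Where it says the series, first, only, none or still open, it means among the compounds named here.

Measured so far:
compound 1, `OC[C@H]1O[C@@H](n2cnc3c(SCCCc4ccccc4)ncnc32)[C@H](O)[C@@H]1O`, 1350 nM
compound 2, `CCCCSc1nc(N)nc2c1ncn2[C@@H]1O[C@H](CO)[C@@H](O)[C@H]1O`, 12000 nM

Of the compounds shown here, two have been measured in an assay on isolated protein for binding affinity to Equilibrative nucleoside transporter 1 (Homo sapiens); on this read-out lower numbers stand for stronger inhibition and higher numbers for weaker inhibition. Compound 1 gives 1350 nM, and compound 2 gives 12000 nM, the higher of the two numbers; the gap between them lies beyond the usual scatter. The two differ in more than one place, so only their values themselves can be compared.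

Compound 3 is `Nc1nc(SCc2ccccc2[N+](=O)[O-])c2ncn([C@@H]3O[C@H](CO)[C@@H](O)[C@H]3O)c2n1`. It is derived from compound 2 by a single change: 2-nitrophenyl in place of propyl on a saturated chain carbon bound to a sulfur. Within the data shown here, no step between measured compounds isolates this kind of change. Compound 1, however, carries an aromatic ring on its sulfur-bound chain and shows the lower number, which suggests the entering group may be favourable. For compound 3 a lowering of the number is therefore expected, by about an 8.0-fold lower number from compound 2 to compound 3 (0.90 log units; beyond the scatter). The estimate for compound 3 is 1500 nM, within the range 250 nM to 9000 nM.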

Compound 3, half-maximal inhibitory concentration: 4570 nM
The estimate for compound 3 lay 3.0-fold (0.48 log units) below the measured number; measured number inside the range.
By their numbers in this assay, from the lowest: compound 1; then compound 3; then compound 2.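

In this assay, 2-nitrophenyl in place of propyl on a saturated chain carbon bound to a sulfur gives a 2.6-fold lower number from compound 2 to compound 3 (0.42 log units; beyond the scatter). Among these compounds, this is the first step that isolates a change at this position, showing that the chain can carry an aromatic ring with a nitro group and that the number falls, modestly but beyond the usual scatter. Until now the aromatic ring of compound 1 could not be read in this way, as compound 1 differs from compound 2 in more than one place. No measurement shown accounts for the step.

The compounds shown leave open whether the ring alone or its nitro group carries this step, which a plain benzyl group would help to separate. Also open, going by these compounds, is how a carboxylic acid or an amine on that ring would fare.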